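Amino for chloro on the purine-type core of compound 1

This account rests on a few compounds, and the source may have more. Where it says the series, first, only, none or still open, it means among the compounds named here.

Compound 1 `ClCc1ccccc1Cn1cnc2c(Cl)nc(Cl)nc21` is the lower of the two numbers recorded so far. In a functional assay on NCI-H23 cells (Homo sapiens) for cytotoxicity, read by sulforhodamine B assay, with a stated time of 48 h (a higher number here means a weaker inhibitor of growth, a lower number a stronger inhibitor of growth), compound 1 gives 3090 nM. Compound 2 `ClCc1ccccc1Cn1cnc2ncnc(Cl)c21`, which lacks one chloro group on the same core, gives 17400 nM in this assay, a higher number that lies beyond the usual scatter.

Compound 3 `Nc1nc(Cl)c2ncn(Cc3ccccc3CCl)c2n1` has not yet been measured in this assay. It differs from compound 1 by amino in place of chloro on an aromatic carbon, an amino in place of chloro on an aromatic carbon. Going by the values given here, no measured pair covers this exact exchange, so the expectation rests only on the two numbers above. With compound 2 at 17400 nM showing what loss of the chloro group does, a moderate step upward is expected from compound 1 to compound 3, a 2.6-fold higher number from compound 1 to compound 3 (0.41 log units; beyond the scatter), larger than the scatter. For compound 3 the estimate in this assay is 8000 nM, with a range from 2500 nM to 25000 nM.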

Compound 3, concentration for total growth inhibition: 8910 nM
Beside the measured number, compound 3's estimate is 1.1-fold (0.05 log units) below it; measured number inside the range.
By their numbers in this assay, from the lowest: compound 1; then compounds 3 and 2 (each within the scatter of the next).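

Going by these compounds alone, this is the first exchange read at this position. In this assay amino in place of chloro on the aromatic carbon between two ring nitrogen atoms gives a 2.9-fold higher number from compound 1 to compound 3 (0.46 log units; beyond the scatter) as a modest step, so this chloro group can be exchanged without growth inhibition being lost from the measured range. No measurement here accounts for the size of the step.

From the compounds shown here alone, a single exchange at one carbon sets no trend, and how a hydroxyl, a methoxy or a methylamino group at this carbon would compare with amino and chloro remains open. Also open, going by these compounds, is what the remaining chloro group on the shared core and the chloromethyl group each contribute to the numbers of compound 1 and compound 3.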